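The source may report more compounds than this note shows. Statements on the series, on what has been measured and on what is new or still open speak of the compounds shown alone.

Going by the values given here, in an ADME assay on MRC5 cells (Homo sapiens) for cytotoxicity, read by MTT assay, with a stated time of 24 h (a higher number here means that more compound is tolerated, a lower number that less compound is tolerated), compound 1 `CC1(C)[C@H]2CC[C@]1(C)N(Cc1cn(-c3ccc(C#N)cc3)nn1)C(=O)C2` gives 10800 nM and compound 2 `CC1(C)[C@H]2CC[C@]1(C)N(Cc1cn(-c3ccccc3F)nn1)C(=O)C2` gives 15100 nM as the second of only two numbers so far. These two values lie within the scatter of each other, so compound 2 does not stand apart from compound 1 on present data.

The next compound is compound 3 `CC1(C)[C@H]2CC[C@]1(C)N(Cc1cn(-c3ccccc3Cl)nn1)C(=O)C2` and it differs from compound 2 at a single spot: chloro in place of fluoro on an aromatic carbon with chloro in place of fluoro on an aromatic carbon, ortho to a large group, so that 2-fluorophenyl becomes 2-chlorophenyl.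

Among the compounds with values here, no measured step makes this exact exchange. Within the data shown here, the only measured step is a 1.4-fold higher number from compound 1 to compound 2 (0.15 log units; within the scatter) and it is a larger swap of the whole aromatic group, yet it stays within the scatter. A single-atom exchange is therefore not expected to move the number beyond the scatter in this assay and no clear direction can be expected either. The estimated change is a 1.1-fold lower number from compound 2 to compound 3 (0.05 log units; within the scatter) and this expected step is within the scatter. For compound 3 the estimated value is 13500 nM and the expected range runs from 7000 nM to 26000 nM on present evidence.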

Compound 3, half-maximal cytotoxic concentration: 4130 nM
Compound 3: the middle estimate sits 3.3-fold (0.51 log units) above what was measured; the measured number lies below the stated range.
By their numbers in this assay, from the lowest: compound 3; then compounds 1 and 2 (each within the scatter of the next).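

In this assay, going by these compounds alone, a change of a single atom moves the number beyond the scatter for the first time: with chloro in place of fluoro on an aromatic carbon, ortho to a large group, the result is a 3.7-fold lower number from compound 2 to compound 3 (0.56 log units; beyond the scatter). So this position responds to which halogen it carries, even though the earlier exchange of the whole aromatic group stayed within the scatter (a 1.4-fold higher number from compound 1 to compound 2 (0.15 log units; within the scatter)), and the exchange of 4-cyanophenyl for 2-chlorophenyl now clears it (a 2.6-fold lower number from compound 1 to compound 3 (0.42 log units; beyond the scatter)). No measurement available here bears on why chloro gives the lower number in this test of cell tolerance.

Three compounds cannot show whether this drop belongs to chloro alone or would also appear with bromo, methyl or methoxy at the same spot. Going by these compounds, it also remains open whether chloro would give a similar number at another place on the phenyl ring, and whether an amine or a carboxylic acid on that ring would bring the number back towards that of compound 2.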